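A few compounds are considered here, and "the series" means these few. Any claim that something is new, unique, unknown or untested is made for them only; others in the source may bear on it.

Three sulfur-bearing esters of the same bicyclic type were examined in a functional assay on A-375 cells (Homo sapiens) for cytotoxicity, read by MTT assay, with a stated time of 48 h; on this read-out higher numbers stand for weaker inhibition and lower numbers for stronger inhibition. Compound 1 `CC1(C)[C@H](C(=O)OC(c2ccccc2)c2ccccc2)N2C(=O)/C(=C/C(=O)c3ccc([N+](=O)[O-])cc3)[C@H]2[S+]1[O-]` carries the ring sulfur as a sulfoxide and bears a nitrophenyl ketone on the exocyclic double bond; in this assay compound 1 gives 48200 nM. Compound 2 `CC1(C)S[C@@H]2/C(=C\C(=O)c3ccc([N+](=O)[O-])cc3)C(=O)N2[C@H]1C(=O)OC(c1ccccc1)c1ccccc1` keeps the same ketone on a plain sulfide and in this assay compound 2 gives 50300 nM, a value within the scatter of that of compound 1 and the higher of the two numbers. Compound 3 `COC(=O)/C=C1\C[C@H]2SC(C)(C)[C@H](C(=O)OC(c3ccccc3)c3ccccc3)N2C1=O` replaces the aryl ketone with a methyl ester on the exocyclic alkene, and in this assay compound 3 reaches only the assay limit, > 100000 nM, a limit at which (the limit of > 100000 nM in this assay, at which 1 of the 3 values shown sits).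

Compound 4 `CC1(C)S[C@@H]2/C(=C\C(=O)c3ccc(Cl)cc3)C(=O)N2[C@H]1C(=O)OC(c1ccccc1)c1ccccc1` differs from compound 2 in one place: chloro in place of nitro on an aromatic carbon. Among the measured compounds shown here, no measured pair in this set makes that change, so what it does to cytotoxicity is unknown here. Both aryl ketones measured sit close together, and the chloro analogue is expected to stay in the same weak region, with a step from compound 2 to compound 4 of a 1.2-fold higher number from compound 2 to compound 4 (0.08 log units; within the scatter), not clearly beyond the scatter. Compound 4 is therefore estimated at 60000 nM, with a plausible range from 25000 nM to 150000 nM.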

Compound 4, half-maximal inhibitory concentration: 48600 nM
The estimate for compound 4 lay 1.2-fold (0.09 log units) above the measured number; low and high end bracket the measured number.
By their numbers in this assay, from the lowest: compounds 1, 4 and 2 (each within the scatter of the next). At a limit, above all of these: compound 3.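

Among the compounds shown here, the exchange of 4-nitrophenyl for 4-chlorophenyl on the ketone gives a 1.0-fold lower number from compound 2 to compound 4 (0.01 log units; within the scatter) in this assay and is the first direct reading of a change on this aromatic ring. The nitro group, with its 3 heavy atoms and 2 hydrogen-bond acceptors, gives way to a single chlorine para to a large group, and the number does not move beyond the scatter. In this pair, then, the nitro group and its hydrogen-bond acceptors are not required for the weak cytotoxicity seen, though nothing shown here bears on why the two groups read alike.

On these data alone, only nitro and chloro have been read at this place on the ring, so it remains open whether an amine, a carboxylic acid or a methoxy group there would leave the number in the same region. Also open, as far as these compounds go, is whether any group on this ring can move the number beyond the scatter at all, and whether a chloro compound carrying the ring sulfur as a sulfoxide would read like compound 4.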